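This account rests on a few compounds, and the source may have more. Where it says the series, first, only, none or still open, it means among the compounds named here.

Measured compounds:
compound 1 `CCCN(C(=O)CC(=O)O)C1=C(C)C[C@H](c2ccc(N)cc2)N([C@@H](C)c2ccc(OC)cc2)C1=O` — 18 nM
compound 2 `CCCN(C(=O)CCN)C1=C(C)CC(c2ccccc2)N(CCC(=O)O)C1=O` — > 1000000 nM

In an assay on K562 cells for inhibition of integrin alpha-5/beta-1 (Homo sapiens) (on this read-out lower numbers stand for stronger inhibition and higher numbers for weaker inhibition), compound 1 gives 18 nM. For compound 2 the read-out is only a limit of this assay, not a number: compound 2 gives > 1000000 nM. This places compound 2 at the limit of > 1000000 nM in this assay, at which 1 of the 2 values shown sits, so its standing is known only as lying beyond that limit, with no number to set it against compound 1.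

Compound 3 `CCCN(C(=O)CCCCCN)C1=C(C)CC(c2ccccc2)N(CCC(=O)O)C1=O` is not yet measured in this assay. It differs from compound 2 in one place: 3-aminopropyl in place of amino on a saturated chain carbon, two bonds along the chain from a carbonyl carbon. Going by the values given here, no measured pair shows a step of this kind, so no size or direction can be read from the data. The account therefore expects compound 3 to remain near the limit at which compound 2 sits, with a step of a number no higher from compound 2 to compound 3 (the limit leaves the size open) that is estimated to be none beyond the scatter. The estimate for compound 3 in this assay is 1000000 nM, within a range from 100000 nM to 10000000 nM.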

Compound 3, half-maximal inhibitory concentration: > 1000000 nM
Compound 3: no number, only a limit (the forecaster's own chance of this, stated with the estimate: 85%); the middle value lies on the limit itself.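

In this assay, compound 2 and compound 3 each give only a limit and not a number, so no step between them can be read: the limit of > 1000000 nM in this assay, at which 2 of the 3 values shown sit.

The compounds shown leave open how far either compound lies beyond that limit, and whether 3-aminopropyl in place of amino changes inhibition at all.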